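A carbonyl step at the limit of the antiproliferative assay

The compounds below may be only part of what the source reports. "The series", "measured", "known", "first", "only" and "open" are said of these compounds alone.

Of the compounds shown here, three sharing one core have been tested in a functional assay on OVCAR-3 cells (Homo sapiens) for antiproliferative activity, read by MTT assay, with a stated time of 24 h (on this read-out higher numbers stand for weaker inhibition and lower numbers for stronger inhibition), so far. Compound 1 (`Cc1ccccc1NNC(=O)c1ccc(NS(=O)(=O)c2cnc(O)nc2O)cc1`) returns > 20000 nM as a limit of the assay and not a number. For the measured compounds named here, compound 2 (`O=C(NNc1ccccc1F)c1cccc(NS(=O)(=O)c2cnc(O)nc2O)c1`) gives 17000 nM as the only true number in the set. Compound 3 (`Cc1cccc(NNC(=O)c2ccccc2NS(=O)(=O)c2cnc(O)nc2O)c1`) returns > 20000 nM in this assay as a limit as well. Compound 3 therefore stands with compound 1 at the limit of > 20000 nM in this assay, at which 2 of the 3 values shown sit, and has no number of its own.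

Compound 4 (`Cc1ccc(C(=O)NNC(=O)c2ccccc2NS(=O)(=O)c2cnc(O)nc2O)cc1`) departs from compound 3 in one place: (4-methylphenyl)carbonyl in place of 3-methylphenyl on an amine nitrogen; (4-methylphenyl)carbonyl takes the place of 3-methylphenyl on an amine nitrogen. Going by the values given here, no measured step between closely matched compounds is available as a guide, so no change beyond the scatter is expected in this assay. The expected change is a number no higher from compound 3 to compound 4 (the limit leaves the size open) and it rests on little data. Compound 4 is estimated at 20000 nM with an expected range from 9000 nM to 40000 nM and may well return only a limit.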

Compound 4, half-maximal inhibitory concentration: 12900 nM
Compound 4: the middle estimate sits 1.6-fold (0.19 log units) above what was measured; the measured number falls inside the stated range.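

In this assay, for the compounds shown here, putting (4-methylphenyl)carbonyl in place of 3-methylphenyl on an amine nitrogen gives an at least 1.5-fold lower number from compound 3 to compound 4 (0.19 log units; that floor lies within the scatter), the first step between closely matched compounds in this set. Compound 4 gives a true number of 12900 nM, so this amine nitrogen can carry a carbonyl-bearing group and still give a reading within the range of the assay. The value of compound 3 is a limit and not a number, and the real size of the step stays open because of that limit: the limit of > 20000 nM in this assay, at which 2 of the 4 values shown sit.

The compounds shown do not separate the effect of the added carbonyl from that of the different methyl placement in the two group names. They also leave open how the number would respond if an amine or a carboxylic acid replaced the methyl on the (4-methylphenyl)carbonyl group.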